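This account rests on a few compounds, and the source may have more. Where it says the series, first, only, none or still open, it means among the compounds named here.

Compound 1 `O=C(Nc1ccccc1)c1cc(Oc2ccc(/C=C/c3ccccn3)cc2)ccn1` and compound 2 `COc1ccc(NC(=O)c2cc(Oc3ccc(/C=C/c4ccccn4)cc3)ccn2)cc1` share one core and differ in a single place: compound 2 carries methoxy in place of hydrogen on an aromatic carbon. In a functional assay on A549 cells (Homo sapiens) for antiproliferative activity, read by CCK-8 assay, with a stated time of 48 h (on this read-out lower numbers stand for stronger inhibition and higher numbers for weaker inhibition), compound 1 gives 19100 nM, and compound 2 gives 20000 nM, so the change made a 1.0-fold higher number from compound 1 to compound 2 (0.02 log units; within the scatter), a step that is within the scatter.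

Compound 3 `O=C(NCc1ccccc1)c1cc(Oc2ccc(/C=C/c3ccncc3)cc2)ccn1` is built on a different core; the difference between the two cores is not broken down here. In this assay compound 3 gives 17000 nM.

Compound 4 `COc1ccc(CNC(=O)c2cc(Oc3ccc(/C=C/c4ccncc4)cc3)ccn2)cc1` carries the same change on the core of compound 3: methoxy in place of hydrogen on an aromatic carbon. Because the matching step from compound 1 to compound 2 was a 1.0-fold higher number from compound 1 to compound 2 (0.02 log units; within the scatter), the step from compound 3 to compound 4 is expected to be a 1.0-fold higher number from compound 3 to compound 4 (0.01 log units; within the scatter), also small. Compound 4 is therefore estimated at 17500 nM, with a likely range from 9000 nM to 35000 nM.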

Compound 4, half-maximal inhibitory concentration: 19300 nM
Estimate against measurement, compound 4: 1.1-fold (0.04 log units) below; the measured number falls inside the stated range.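

In this assay, methoxy in place of hydrogen on an aromatic carbon gives a 1.1-fold higher number from compound 3 to compound 4 (0.06 log units; within the scatter), a small step like the one seen on the core of compound 1. Set side by side, the two steps agree: the same change on two cores in this assay, a 1.0-fold higher number (0.02 log units; within the scatter) from compound 1 to compound 2 and a 1.1-fold higher number (0.06 log units; within the scatter) from compound 3 to compound 4, 1.1-fold (0.04 log units) apart, within the scatter of two such steps. This shows that the change carries across these two cores with little visible effect, but two steps that both lie within the scatter cannot show that a change with a real effect would carry across equally well.

The compounds shown leave open whether another group in the same place, such as an amine or a carboxylic acid, would shift the number beyond the scatter. They also leave open whether methoxy elsewhere on that ring would behave the same way.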